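Swapping the Pyridine Ring for Cyclopropyl on the Amide

The compounds below may be only part of what the source reports. "The series", "measured", "known", "first", "only" and "open" are said of these compounds alone.

Three measured compounds share one core and differ only in the group carried on the amide nitrogen. Compound 1 `O=C(Nc1ccccc1O)c1cccc(N2C(=O)c3ccccc3C2=O)c1` carries 2-hydroxyphenyl there, and in an in vitro functional assay on HEK293-A cells for antagonist activity at metabotropic glutamate receptor 5 (Rattus norvegicus), read by calcium flux (on this read-out higher numbers stand for weaker inhibition and lower numbers for stronger inhibition), compound 1 gives 77 nM. Compound 2 `O=C(Nc1cccc(Cl)c1)c1cccc(N2C(=O)c3ccccc3C2=O)c1` carries 3-chlorophenyl, and in this assay compound 2 gives 1780 nM. Compound 3 `O=C(Nc1cccnc1)c1cccc(N2C(=O)c3ccccc3C2=O)c1` carries pyridin-3-yl. For compound 3 the assay reports only a limit, > 30000 nM, in this assay. Compound 3 is therefore the weakest of the three: an at least 380-fold higher number from compound 1 to compound 3 (2.59 log units; beyond the scatter) and an at least 16-fold higher number from compound 2 to compound 3 (1.22 log units; beyond the scatter) are both large, as is a 23-fold higher number from compound 1 to compound 2 (1.36 log units; beyond the scatter).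

Compound 4 `O=C(NC1CC1)c1cccc(N2C(=O)c3ccccc3C2=O)c1` brings a different kind of change: cyclopropyl in place of pyridin-3-yl on an amide-type nitrogen. For the measured compounds named here, none of the measured steps swaps an aromatic ring for a small non-aromatic ring, so they give no direct guide. Going by the values given here, they show only that each change away from compound 1 has weakened inhibition. Compound 3 sits at the limit described by the limit of > 30000 nM in this assay, at which 1 of the 3 values shown sits. Starting from a limit, the step of an at least 1.5-fold lower number from compound 3 to compound 4 (0.17 log units; that floor lies within the scatter) is expected to be modest and uncertain in direction. Compound 4 is estimated at 20000 nM, within 2000 nM to 100000 nM.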

Compound 4, half-maximal inhibitory concentration: > 30000 nM
Compound 4 ended at the assay's limit; the forecaster's own chance of this, stated with the estimate: 55%; middle value at least 1.5-fold (0.17 log units) from the limit.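

In this assay compound 4 gives > 30000 nM as a limit of the assay, not a number. Compound 3 and compound 4 both stand at a limit, so the step between them cannot be read, and the small non-aromatic cyclopropyl shows no more inhibition than the assay's limit allows: the limit of > 30000 nM in this assay, at which 2 of the 4 values shown sit. Measured against the two compounds with readable values, the change remains large (an at least 16-fold higher number from compound 2 to compound 4 (1.22 log units; beyond the scatter) and an at least 380-fold higher number from compound 1 to compound 4 (2.59 log units; beyond the scatter)), so among the groups shown on this amide nitrogen, only 2-hydroxyphenyl and 3-chlorophenyl give a readable value.

As far as these compounds go, whether a larger non-aromatic group, such as a longer butyl chain or a cyclohexyl ring, would bring the value below the limit remains open. So does whether a phenyl ring carrying an amine or a carboxylic acid instead of the hydroxyl would keep the inhibition of compound 1.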